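This account rests on a few compounds, and the source may have more. Where it says the series, first, only, none or still open, it means among the compounds named here.

Measured so far in a physicochemical assay for solubility, read by HPLC, using the shake flask method, in phosphate buffer, with a stated time of 20 h, at pH 6.5 (a higher number here means a more soluble compound, a lower number a less soluble compound), for the series
- compound 1 `C[C@@H]1CN(c2nccc3[nH]c(-c4ccc(F)c(F)c4)nc23)C[C@H](C)N1` gives 190000 nM
- compound 2 `Fc1ccc(-c2nc3c(N4CCCNCC4)nccc3[nH]2)cc1F` gives 165000 nM

Compound 2 at 165000 nM stands within the scatter of compound 1 at 190000 nM and the two cannot be ranked.

Next in view is compound 3 `NC1CCN(c2nccc3[nH]c(-c4ccc(F)c(F)c4)nc23)CC1` with the change 4-aminopiperidin-1-yl in place of 1,4-diazepan-1-yl on an aromatic carbon on an aromatic carbon of a six-membered aromatic ring with 1 nitrogen, part of a fused or bridged system of two rings. Within the data shown here, the one measured step that bears on it is a 1.2-fold lower number from compound 1 to compound 2 (0.06 log units; within the scatter) and this is also an exchange of the group at that place. On that ground no step beyond the scatter is expected in this assay for the new exchange. Among the measured compounds shown here, the expectation rests on this single pair, and no measured compound carries 4-aminopiperidin-1-yl. The estimated change is a 1.0-fold lower number from compound 2 to compound 3 (0.01 log units; within the scatter) and it is expected to be small. For compound 3 the estimated value is 160000 nM with an expected range from 80000 nM to 280000 nM in this series.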

Compound 3, solubility: 200000 nM
Beside the measured number, compound 3's estimate is 1.3-fold (0.10 log units) below it, within the range that was stated.
By their numbers in this assay, from the lowest: compounds 2, 1 and 3 (each within the scatter of the next).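

Exchanging the 1,4-diazepan-1-yl group, one seven-membered non-aromatic ring with 2 hetero atoms, for 4-aminopiperidin-1-yl, one six-membered non-aromatic ring with 1 hetero atom, gives in this assay a 1.2-fold higher number from compound 2 to compound 3 (0.08 log units; within the scatter), and the exchange of 3,5-dimethylpiperazin-1-yl for the same group gives a 1.1-fold higher number from compound 1 to compound 3 (0.02 log units; within the scatter). At this aromatic carbon next to the ring nitrogen, the three groups therefore cannot be ranked, and neither ring size nor the placing of the second nitrogen in or outside the ring separates the values of these three compounds. Nothing available accounts for these values or bears on the result.

Every group shown at this place is a saturated nitrogen ring that carries a second nitrogen, so the series gives no reading for a morpholin-4-yl group, an open-chain amine or a carboxylic acid there. As far as these compounds go, whether any exchange at this carbon can produce a step beyond the scatter, and whether the same holds with a different group elsewhere on the shared core, remains open.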